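The compounds below may be only part of what the source reports. "The series", "measured", "known", "first", "only" and "open" are said of these compounds alone.

Compound 1, `Nc1cccc(CCCCCC(=O)N2CCOC2=O)c1`, gives > 20000 nM in an assay on HEK293 cells for inhibition of N-acylethanolamine-hydrolyzing acid amidase (Rattus norvegicus), read by LC-MS, with a stated time of 30 min; a lower number here means a stronger inhibitor, a higher number a weaker inhibitor; this is a limit of the assay, not a number.
Compound 2, `O=C(CCCCCc1ccc(Cl)cc1)N1CCOC1=O`, gives 4600 nM in this assay.

Within the data shown here, of the two values shown, only that of compound 2 is an actual measured number; the other sits at the limit of > 20000 nM in this assay, at which 1 of the 2 values shown sits, so compound 2 can only be said to lie inside the range the assay is able to report. Compound 3, `O=C(CCCCCc1ccc(O)cc1)N1CCOC1=O`, differs from compound 2 in one place: hydroxy in place of chloro on an aromatic carbon. Among the measured compounds shown here, no measured pair of compounds shows a change of this kind, so the size of the step cannot be read from the data and has to be estimated. A small-to-moderate weakening is expected, of about a 1.7-fold higher number from compound 2 to compound 3 (0.24 log units; within the scatter), although a result inside the usual scatter would not be surprising. Compound 3 is therefore expected to give roughly 8000 nM in this assay, within a range of 2500 nM to 25000 nM, with a fair chance that only a limit is reported.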

Compound 3, half-maximal inhibitory concentration: 61 nM
Compound 3: middle estimate off by 130-fold (2.12 log units), on the high side; the measured number lies below the stated range.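

Until now, no pair of compounds had shown how much a change at this place could matter. Putting hydroxy in place of chloro on an aromatic carbon, para to a large group, gives a 75-fold lower number from compound 2 to compound 3 (1.88 log units; beyond the scatter) in this assay, so this place on the ring is far from indifferent, even though only one heavy atom is exchanged for another. The change also adds a hydrogen-bond donor and a hydrogen-bond acceptor, but nothing measured here shows what lies behind the step.

The compounds shown leave open whether a methoxy, an amine or a carboxylic acid at this same place would match hydroxy. They also leave open whether a longer or shorter chain, with hydroxy kept in place, would hold the value of compound 3.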